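Branching the thiocarbamate chain at the piperidine carbamate

The source may hold more compounds than are shown below. What is called first, only, known or untested is meant among the compounds shown, and "the series" means these compounds.

Compound 1 `CC(C)OC(=O)N1CCC(Oc2ncnc3c2CCN3c2ccc(S(C)(=O)=O)cc2F)CC1` and compound 2 `CCSC(=O)N1CCC(Oc2ncnc3c2CCN3c2ccc(S(C)(=O)=O)cc2F)CC1` share a core and differ only at the carbonyl substituent. In a functional assay on CHO-K1 cells for agonist activity at Glucose-dependent insulinotropic receptor (Homo sapiens), read by a luciferase reporter, with a stated time of 5 h (on this read-out higher numbers stand for an effect only at larger amounts of compound and lower numbers for an effect already at smaller amounts), compound 1 gives 50.1 nM, and in this assay compound 2 gives 31.6 nM. Within the data shown here, the step of a 1.6-fold lower number from compound 1 to compound 2 (0.20 log units; within the scatter) is the only measured comparison, and compound 2 stands with the lowest of the two numbers, though its gap to compound 1 lies within the scatter, so no order between them can be claimed.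

Compound 3 `CC(C)SC(=O)N1CCC(Oc2ncnc3c2CCN3c2ccc(S(C)(=O)=O)cc2F)CC1` has not yet been measured. It is drawn from compound 2 by the change (methyl in place of hydrogen on a saturated chain carbon bound to a saturated chain carbon and a sulfur), which read one bond further out is ethylsulfanyl to isopropylsulfanyl. Among the measured compounds shown here, no measured step adds a methyl on this chain; the one step that exists, from an isopropoxy to an ethylsulfanyl group, stayed within the scatter. Compound 1 already carries the branched chain on an oxygen and sits close to compound 2. The step of a 1.0-fold higher number from compound 2 to compound 3 (0.01 log units; within the scatter) is therefore expected to stay within the scatter, with no direction favoured. For compound 3 the estimate in this assay is 32 nM, with a range from 12 nM to 85 nM.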

Compound 3, half-maximal effective concentration: 10 nM
The estimate for compound 3 lay 3.2-fold (0.51 log units) above the measured number; the whole stated range lies above it.
By their numbers in this assay, from the lowest: compound 3; then compounds 2 and 1 (each within the scatter of the next).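

In this assay, among these compounds, the methyl on the saturated chain carbon bound to a saturated chain carbon and a sulfur gives a 3.2-fold lower number from compound 2 to compound 3 (0.50 log units; beyond the scatter), the first step at this carbonyl substituent that lies beyond the scatter, so this position does respond to a small change, though only modestly. With the branched chain kept, the exchange at the carbonyl substituent gives a 5.0-fold lower number from compound 1 to compound 3 (0.70 log units; beyond the scatter), also beyond the scatter, whereas the earlier exchange of isopropoxy for ethylsulfanyl, a 1.6-fold lower number from compound 1 to compound 2 (0.20 log units; within the scatter), could not be told from the scatter. No measurement in hand accounts for either step.

Going by these compounds, it remains open whether the gain from branching belongs to the sulfur series alone, a question that an ethoxy group on the carbonyl carbon, set against isopropoxy, could answer. On these data alone, it is equally open whether the trend goes on or reverses with a tert-butylsulfanyl group, a cyclopropylsulfanyl group or a longer chain such as n-butylsulfanyl.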